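The compounds below may be only part of what the source reports. "The series", "measured", "known", "first", "only" and "open" are said of these compounds alone.

Three compounds share one core and differ only in the group on a double-bonded chain carbon bound to a double-bonded ring carbon. In a functional assay on JAR cells (Homo sapiens) for inhibition, read by MTT assay, with a stated time of 72 h, tested at 10 uM (on this read-out lower numbers stand for less inhibition and higher numbers for more inhibition at the one concentration tested (going by the name of the read-out)), compound 1 `CCOC(=O)C1=C(Nc2ccccc2)S/C(=C\c2ccc(OC)cc2)C1=O` gives 32.9%, while compound 2 `CCOC(=O)C1=C(Nc2ccccc2)S/C(=C\c2ccc(Br)c(O)c2)C1=O` gives 39.8%; the step of a number 6.9 percentage points higher from compound 1 to compound 2 (within the scatter) changes nothing that can be trusted. Compound 3 `CCOC(=O)C1=C(Nc2ccccc2)S/C(=C\c2cc[nH]c2)C1=O` gives 19.5% in this assay, the lowest of the three numbers, with the step of a number 13.4 percentage points lower from compound 1 to compound 3 (beyond the scatter) and the step of a number 20.3 percentage points lower from compound 2 to compound 3 (beyond the scatter) both beyond the scatter. Compound 3 thus has the lowest inhibition in this assay of the compounds measured here.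

Compound 4 `CCOC(=O)C1=C(Nc2ccccc2)S/C(=C\c2cc3cnccc3[nH]2)C1=O` takes the step from compound 3 described as a group of 9 heavy atoms (7 carbon, 2 nitrogen; one five-membered aromatic ring with 1 hetero atom, one six-membered aromatic ring with 1 hetero atom) in place of a group of 5 heavy atoms (4 carbon, 1 nitrogen; one five-membered aromatic ring with 1 hetero atom), on a double-bonded chain carbon bound to a double-bonded ring carbon. The two steps that bear on it are those leading into compound 3: in each of them the 1H-pyrrol-3-yl group took the place of a six-membered aromatic group and inhibition fell modestly. Compound 4 moves the other way, from the 1H-pyrrol-3-yl group to a larger group that again contains a six-membered aromatic ring, so a modest rise is expected rather than a fall. Compound 4 is therefore estimated to give 30% in this assay, within a range of 15% to 45%, which means an expected step of a number 10.5 percentage points higher from compound 3 to compound 4 (beyond the scatter).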

Compound 4, a percentage reported as inhibition, at one concentration (the size of the read-out at that concentration, not a potency): < 10%
Compound 4 gave a limit, no number; the forecaster's own chance of this, stated with the estimate: 0%; middle value at least 20 percentage points away from the limit.
By their numbers in this assay, from the lowest: compound 3; then compounds 1 and 2 (each within the scatter of the next). At a limit, below all of these: compound 4.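

In this assay the reading for compound 4 is a limit and not a number: the limit of < 10% in this assay, at which 1 of the 4 values shown sits. On the double-bonded chain carbon bound to a double-bonded ring carbon, a six-membered aromatic ring alone therefore does not carry inhibition: the group that joins a five-membered aromatic ring to a six-membered aromatic ring with a hetero atom gives a step of a number at least 22.9 percentage points lower from compound 1 to compound 4 (beyond the scatter) and another a number at least 29.8 percentage points lower from compound 2 to compound 4 (beyond the scatter), so the larger group of 9 heavy atoms falls clearly short of the two groups with a six-membered ring of carbon only. Against the smaller 1H-pyrrol-3-yl group the reading is a number at least 9.5 percentage points lower from compound 3 to compound 4 (that floor lies within the scatter), which means a real fall on enlarging that group is possible but not established, and the rise that the earlier compounds seemed to point to does not appear.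

The compounds shown do not separate the added ring as such from the nitrogen in it, which an indol-2-yl group, with its six-membered ring of carbon only, or a simple pyridin-3-yl group would help to do. As far as these compounds go, how far inhibition by compound 4 lies under its limit also stays open, and so does whether an amine or a carboxylic acid on the phenyl ring of compounds 1 and 2 would change the picture.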